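This account rests on a few compounds, and the source may have more. Where it says the series, first, only, none or still open, it means among the compounds named here.

Working notes on the series in a physicochemical assay for acid dissociation.

Compound 1 `COc1cccc(CNCCCNc2ccnc3cc(C4CCCCC4)ccc23)c1O` carries a 2-hydroxy-3-methoxyphenyl group on the saturated chain carbon bound to the amine nitrogen; in this assay compound 1 gives 9.47. Compound 2 `COc1ccc(F)cc1CNCCCNc1ccnc2cc(C3CCCCC3)ccc12`, the 5-fluoro-2-methoxyphenyl analogue, gives 9.47, and compound 3 `c1ccc(Cc2ccc3c(NCCCNCc4ccco4)ccnc3c2)cc1`, with a furan-bearing chain on a different core, gives 9.47. Compound 1 therefore stands level with compound 2 and compound 3 at the digits shown; the one measured step, no change at the digits printed from compound 1 to compound 2 (within the scatter), shows no movement beyond the scatter when the aryl group on the chain is exchanged.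

Compound 4 `COc1cccc(CNCCCNc2ccnc3cc(Oc4cccc(N(C)C)c4)ccc23)c1O` is the next member. It differs from compound 1 at the core rather than on the chain: 3-(dimethylamino)phenoxy in place of cyclohexyl on an aromatic carbon.

Among the measured compounds shown here, no measured step touches the substituent on an aromatic carbon of the core, so the only guidance is indirect. The exchange from compound 1 to compound 2 left this assay flat, and compound 3 shows the same reading on a different core, which suggests the reading is set by the chain amine and is insensitive to remote changes. The step of no change at the digits printed from compound 1 to compound 4 (within the scatter) is expected to stay within the scatter. Compound 4 is estimated at 9.47, with a range from 9.1 to 9.8.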

Compound 4, acid dissociation constant: 9.28
The estimate for compound 4 lay 0.19 log units above the measured number, within the range that was stated.
By their numbers in this assay, from the lowest: compounds 4, 1, 2 and 3 (each within the scatter of the next).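

Among the compounds shown here, the first exchange at the substituent on an aromatic carbon of the core, 3-(dimethylamino)phenoxy in place of cyclohexyl, gives in this assay a number 0.19 log units lower from compound 1 to compound 4 (within the scatter). For the compounds shown here, until now, the only single-place step was on the aryl group of the chain; this one shows that the reading also stays within the scatter when a change is made on the core, even though the entering group is larger than cyclohexyl, contains an aromatic ring and carries hydrogen-bond acceptors where cyclohexyl has none. No supporting data are available to explain this outcome.

With only cyclohexyl and 3-(dimethylamino)phenoxy compared at this aromatic carbon, a single step gives no trend for the position, and the flat reading cannot be extended to other substituents there. From the compounds shown here alone, whether a carboxylic acid or a trifluoromethyl group at the same place, or a longer chain carrying the amine nitrogen, would also leave this assay within the scatter remains open.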